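The compounds below may be only part of what the source reports. "The series", "measured", "known", "first", "only" and "open" are said of these compounds alone.

- compound 1 `Cc1cc(-n2nccn2)cc(C(=O)NNS(=O)(=O)c2ccccc2)c1F` gives 53 10^-6 cm/s
- compound 2 `CCCOc1cccc(C(=O)NNS(=O)(=O)c2ccccc2F)c1` gives 77.3 10^-6 cm/s

In an ADME assay on Caco-2 cells (Homo sapiens) for permeability, read by LC-MS, in the apical to basolateral direction, with a stated time of 90 min (on this read-out lower numbers stand for lower permeability and higher numbers for higher permeability), compound 2 gives 77.3 10^-6 cm/s and lies within the usual scatter of compound 1. Among the measured compounds shown here, compound 3 `O=C(NNS(=O)(=O)c1ccccc1F)c1cccc(I)c1` carries iodo in place of propoxy on an aromatic carbon and no measured pair shows this change. For the measured compounds named here, with no such pair to lean on, the expectation in this assay stays close to compound 2 at 77.3 10^-6 cm/s and no step beyond the scatter is expected. The estimated step is a 1.3-fold lower number from compound 2 to compound 3 (0.11 log units; within the scatter) and it is a small one. For compound 3 the estimate is 60 10^-6 cm/s with an expected range from 28 10^-6 cm/s to 120 10^-6 cm/s as the working figure.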

Compound 3, apparent permeability: 60.4 10^-6 cm/s
Estimate against measurement, compound 3: 1.0-fold (0.00 log units) below; the measured number falls inside the stated range.
By their numbers in this assay, from the lowest: compounds 1, 3 and 2 (each within the scatter of the next).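

In this assay, among the compounds shown here, the first one-place step, iodo in place of propoxy, gives a 1.3-fold lower number from compound 2 to compound 3 (0.11 log units; within the scatter) at this aromatic carbon. This position, meta to a large group, therefore carries either group with no step beyond the scatter. No measured evidence bears on this result.

On these data alone, whether an amine, a carboxylic acid or a longer alkoxy chain at this carbon would stay within the scatter of compound 2 remains open. As far as these compounds go, how compound 1 relates to this position also remains open, since it differs from both compounds in more than one place.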